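Swapping the Benzoyl Ring on a Thiazole Hydrazone Series

This account rests on a few compounds, and the source may have more. Where it says the series, first, only, none or still open, it means among the compounds named here.

Measured compounds, all tested in a functional assay on MCF7 cells (Homo sapiens) for inhibition, read by MTT assay, with a stated time of 72 h; on this read-out lower numbers stand for stronger inhibition and higher numbers for weaker inhibition:
- compound 1 `CN(C(=O)NC(=O)c1ccc(F)c(F)c1)c1nc(C(F)(F)F)c(C(=O)N/N=C/c2ccc([N+](=O)[O-])cc2)s1` gives 4.81 ug/mL
- compound 2 `CN(C(=O)NC(=O)c1ccc(F)c(F)c1)c1nc(C(F)(F)F)c(C(=O)N/N=C/c2cccc(C(F)(F)F)c2)s1` gives 4.15 ug/mL
- compound 3 `CN(C(=O)NC(=O)c1ccc(F)c(F)c1)c1nc(C(F)(F)F)c(C(=O)N/N=C/c2ccccc2C(F)(F)F)s1` gives 8.21 ug/mL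

Compound 2 has the lowest of the three numbers, but its neighbours sit close: compound 1 is a 1.2-fold lower number from compound 1 to compound 2 (0.06 log units; within the scatter) away and compound 3 a 2.0-fold higher number from compound 2 to compound 3 (0.30 log units; within the scatter), and compound 1 to compound 3 is a 1.7-fold higher number from compound 1 to compound 3 (0.23 log units; within the scatter). All three steps are within the scatter, so nothing separates these compounds on the numbers shown. They differ only in the aryl on the carbon with a double bond to nitrogen.

Compound 4 `CN(C(=O)NC(=O)c1ccc(Cl)cc1Cl)c1nc(C(F)(F)F)c(C(=O)N/N=C/c2cccc(C(F)(F)F)c2)s1` is not yet measured. Its change from compound 2 lies elsewhere, at the other end of the shared core: 2,4-dichlorophenyl in place of 3,4-difluorophenyl on a carbonyl carbon. Among the measured compounds shown here, no measured step touches this position, so none of the three steps bears directly on it; what the measured steps do show is that changing one aryl end of this core, at least at the hydrazone side, moved the numbers little. Without data at the benzoyl side, the fair expectation is a step of no clear size or direction beyond the scatter.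

Compound 4 is therefore estimated at 4.5 ug/mL, in the range 1.5 ug/mL to 13 ug/mL, which means an expected step of a 1.1-fold higher number from compound 2 to compound 4 (0.04 log units; within the scatter) from compound 2.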

Compound 4, half-maximal inhibitory concentration: 10.7 ug/mL
Beside the measured number, compound 4's estimate is 2.4-fold (0.38 log units) below it; measured number inside the range.
By their numbers in this assay, from the lowest: compounds 2, 1, 3 and 4 (each within the scatter of the next, the first and the last beyond it).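

Among the compounds shown here, the benzoyl end of the shared core shows a response in this assay that the earlier compounds could not reveal: 2,4-dichlorophenyl in place of 3,4-difluorophenyl on a carbonyl carbon gives a 2.6-fold higher number from compound 2 to compound 4 (0.41 log units; beyond the scatter), a modest step and the first one here beyond the scatter, whereas all three steps among the aryl groups on the carbon with a double bond to nitrogen stay within it. The leaving and entering groups have the same count of heavy atoms and one aromatic ring each, but they differ both in the halogen and in the numbers in their names, so this single step cannot separate the switch from fluorine to chlorine from the change in substitution pattern. Nothing available bears on why the number differs between these two compounds.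

As far as these compounds go, it remains open whether 3,4-dichlorophenyl or 2,4-difluorophenyl would read closer to compound 2 or to compound 4, and whether the step would hold with the 4-nitrophenyl of compound 1 or the 2-(trifluoromethyl)phenyl of compound 3 at the other end. From the compounds shown here alone, the effect of an amine or a methoxy group on the benzoyl ring is also open.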